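Ethyl for methyl on the amide of compound 2

The source may hold more compounds than are shown below. What is called first, only, known or untested is meant among the compounds shown, and "the series" means these compounds.

Compound 1, `CNC(=O)c1cc(Oc2ccc(NC(=O)c3cc4cccnc4n(-c4ccc(Br)cc4F)c3=O)cc2)ccn1`, gives 1950 nM in a functional assay on HT-29 cells (Homo sapiens) for antiproliferative activity, read by MTT assay, with a stated time of 72 h; on this read-out lower numbers stand for stronger inhibition and higher numbers for weaker inhibition.
Compound 2, `CNC(=O)c1cc(Oc2ccc(NC(=O)c3cc4cccnc4n(-c4ccc(C(F)(F)F)cc4Cl)c3=O)cc2)ccn1`, gives 3190 nM in this assay.
Compound 3, `CNC(=O)c1cc(Oc2ccc(NC(=O)c3cc4cccnc4n(-c4ccc(F)c(Cl)c4)c3=O)cc2)ccn1`, gives 1810 nM in this assay.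

Compound 2 gives the highest number of the three, but its gaps to the others are small: a 1.6-fold higher number from compound 1 to compound 2 (0.21 log units; within the scatter), and a 1.8-fold lower number from compound 2 to compound 3 (0.25 log units; within the scatter). The third pair behaves the same way, a 1.1-fold lower number from compound 1 to compound 3 (0.03 log units; within the scatter). All three measured steps exchange one substituted phenyl for another on the aromatic nitrogen of the shared core, and none of them moves the number beyond the scatter.

Compound 4, `CCNC(=O)c1cc(Oc2ccc(NC(=O)c3cc4cccnc4n(-c4ccc(C(F)(F)F)cc4Cl)c3=O)cc2)ccn1`, differs from compound 2 at a different place: methyl in place of hydrogen on a saturated chain carbon bound to an amide-type nitrogen. Among the compounds with values here, no measured step touches this part of the molecule, so there is no direct precedent for it among the three compounds. Within the data shown here, the only evidence available is that the three measured changes, all elsewhere in the structure, left the number essentially where it was. On that basis compound 4 is expected to stay close to compound 2 in this assay, with a step of a 1.0-fold higher number from compound 2 to compound 4 (0.00 log units; within the scatter) that is not expected to exceed the scatter. Compound 4 is therefore estimated at 3200 nM, within a range from 1400 nM to 7500 nM.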

Compound 4, half-maximal inhibitory concentration: 4770 nM
Beside the measured number, compound 4's estimate is 1.5-fold (0.17 log units) below it, within the range that was stated.
By their numbers in this assay, from the lowest: compounds 3, 1, 2 and 4 (each within the scatter of the next, the first and the last beyond it).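

Within the data shown here, the step from methylcarbamoyl to ethylcarbamoyl is the first reading at this end of the molecule, as the earlier steps all exchanged one substituted phenyl for another on the aromatic nitrogen. In this assay, methyl in place of hydrogen on a saturated chain carbon bound to an amide-type nitrogen gives a 1.5-fold higher number from compound 2 to compound 4 (0.17 log units; within the scatter), so this single pair shows that adding 1 carbon here leaves the two compounds indistinguishable in this assay. Nothing available bears on the reason for this result.

The compounds shown leave open whether this tolerance extends further along the chain, for example to a propyl or butyl group, or to a branched isopropyl group, a cyclopropyl ring, or a chain ending in a hydroxyl group or an amine, and also what happens when the methyl is removed to leave a primary carboxamide. From the compounds shown here alone, it also remains open whether ethyl behaves in the same way when paired with the 4-bromo-2-fluorophenyl group of compound 1 or the 3-chloro-4-fluorophenyl group of compound 3.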